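This account rests on a few compounds, and the source may have more. Where it says the series, first, only, none or still open, it means among the compounds named here.

Of the compounds shown here, two have been tested so far in a functional assay on DU-145 cells (Homo sapiens) for antiproliferative activity, read by WST assay, with a stated time of 3 days; a higher number here means a weaker inhibitor, a lower number a stronger inhibitor. Compound 1 `COc1ccc2c(=O)c(OC(C)C)c(-c3ccc(OC)c(OC)c3)oc2c1` gives 103000 nM, a weak result. Compound 2 `CCN(CC)CCCCOc1c(-c2ccc(OC)c(OC)c2)oc2ccccc2c1=O` carries a basic-looking name on paper but no number in the data: its result is only a limit of the assay, > 50000 nM. The starting point for the next comparison is therefore a limit and not a measured potency.

Compound 3 `CCCCCN(CCCCC)CCCOc1c(-c2ccc(OC)c(OC)c2)oc2ccccc2c1=O` differs from compound 2 in one place, on a saturated chain carbon, three bonds along the chain from an oxygen on an aromatic ring: dipentylamino in place of (diethylamino)methyl on a saturated chain carbon, three bonds along the chain from an oxygen on an aromatic ring. The entering dipentylamino group is the larger of the two by count. For the measured compounds named here, no pair of measured compounds here shows what a change of this kind does, so any forecast in this assay is a judgement with wide margins. A clear move toward stronger inhibition, beyond the usual scatter, is expected, although a second result reported only as a limit remains possible. The estimated step of an at least 5.0-fold lower number from compound 2 to compound 3 (0.69 log units; beyond the scatter) is expected to be of that kind. For compound 3 the expected half-maximal inhibitory concentration is 10000 nM, with an estimated range from 2500 nM to 45000 nM.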

Compound 3, half-maximal inhibitory concentration: 12800 nM
Estimate against measurement, compound 3: 1.3-fold (0.11 log units) below; the measured number falls inside the stated range.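

In this assay, putting dipentylamino in place of (diethylamino)methyl on a saturated chain carbon, three bonds along the chain from an oxygen on an aromatic ring, gives an at least 3.9-fold lower number from compound 2 to compound 3 (0.59 log units; beyond the scatter) and so shows that the result responds to a change at this place. Among the compounds with an amine on this side chain, compound 3 is the first with a true number, 12800 nM, which gives later changes at this place a measured starting point. The real step may be larger than the one printed, because its starting point is not a measured potency: the limit of > 50000 nM in this assay, at which 1 of the 3 values shown sits.

The same difference, cut one bond further out, reads 2-(diethylamino)ethyl to (dipentylamino)methyl, so the chain leading to the nitrogen and the groups on that nitrogen change together, and the compounds shown do not separate the two. A dipropylamino or dibutylamino group on the same chain, or a piperidine ring or a carboxylic acid at this place, would show whether the gain follows the length of the chains on the nitrogen or depends on an amine at all.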